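The source may report more compounds than this note shows. Statements on the series, on what has been measured and on what is new or still open speak of the compounds shown alone.

Compound 1 `COC1=C(OC)[C@@]2(OC)c3c(OC)c(OC)c4c(c3O[C@@]23O[C@@H](c2ccccc2)CC=C3C1=O)[C@@H](OC)C[C@H](c1ccccc1)O4` and compound 2 `COC1=C(OC)[C@@]2(OC)c3c(O)c(OC)c4c(c3O[C@@]23O[C@@H](c2ccccc2)CC=C3C1=O)[C@@H](OC)C[C@H](c1ccccc1)O4` were examined in a functional assay on KB cells (Homo sapiens) for cytotoxicity; a higher number here means that more compound is needed for the effect, a lower number that less compound is needed. In this assay compound 1 gives 0.4 ug/mL, and compound 2 gives 0.8 ug/mL. Within the data shown here, of the two numbers known so far compound 2 holds the larger one, yet the step of a 2.0-fold higher number from compound 1 to compound 2 (0.30 log units; within the scatter) stays within the scatter, so the two compounds cannot be told apart on this evidence.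

Compound 3 `COC1=C(OC)[C@@]2(OC)c3c(O)c(OC)c4c(c3O[C@@]23O[C@@H](c2ccccc2)CC=C3C1=O)[C@@H](O)C[C@H](c1ccccc1)O4` has not yet been tested. It differs from compound 2 in one place: hydrogen in place of methyl on an oxygen on a saturated carbon. Among the measured compounds shown here, the only measured step of a related kind is a 2.0-fold higher number from compound 1 to compound 2 (0.30 log units; within the scatter), in which a methyl on an oxygen on an aromatic ring was likewise replaced by hydrogen; that step stayed within the scatter. On this basis compound 3 is expected to show a step of about a 1.5-fold higher number from compound 2 to compound 3 (0.18 log units; within the scatter) in this assay, that is, no change that rises clearly above the scatter. Compound 3 is therefore estimated at 1.2 ug/mL, with a likely range from 0.4 ug/mL to 3.5 ug/mL.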

Compound 3, half-maximal effective concentration: 1.2 ug/mL
Estimate against measurement, compound 3: no gap at the digits printed; the range from low to high includes it.
By their numbers in this assay, from the lowest: compounds 1, 2 and 3 (each within the scatter of the next, the first and the last beyond it).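

In this assay, the methoxy to hydroxy exchange on an oxygen on a saturated carbon gives a 1.5-fold higher number from compound 2 to compound 3 (0.18 log units; within the scatter), so compound 2 and compound 3 cannot be told apart on this evidence. The earlier compounds shown here covered only a methyl on an oxygen on an aromatic ring, whereas this result shows that replacing methyl by hydrogen at this second place, on a saturated carbon, also produces no change beyond the scatter. Nothing measured beyond these cytotoxicity numbers bears on this result.

The compounds shown leave open whether a larger group on this same oxygen, such as an acetyl or a longer alkyl chain, would also stay within the scatter. They also leave open whether an amine in place of the hydroxy would do so.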